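A Phenylsulfonyl Swap Carried to a Second Core

This account rests on a few compounds, and the source may have more. Where it says the series, first, only, none or still open, it means among the compounds named here.

Measured compounds:
Compound 1 `O=C1/C(=C/c2ccncc2)CNC/C1=C\c1ccccc1F` in a functional assay on SMMC-7721 cells (Homo sapiens) for cytotoxicity, read by MTT assay, with a stated time of 24 h (a lower number here means a stronger inhibitor, a higher number a weaker inhibitor), gives 18400 nM
Compound 2 `O=C1/C(=C/c2ccncc2)CN(S(=O)(=O)c2ccccc2)C/C1=C\c1ccccc1F` gives 17500 nM
Compound 3 `O=C1/C(=C/c2ccncc2)CNC/C1=C\c1ccccc1C(F)(F)F` gives 4500 nM

Compound 1 and compound 2 differ by one change, (phenylsulfonyl in place of hydrogen on an amine nitrogen in a ring), and that change gave a 1.1-fold lower number from compound 1 to compound 2 (0.02 log units; within the scatter). Compound 3 differs from compound 1 in its core, (trifluoromethyl in place of fluoro on an aromatic carbon), a change of a 4.1-fold lower number from compound 1 to compound 3 (0.61 log units; beyond the scatter), leaving compound 3 with the lowest number of the three.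

Compound 4 `O=C1/C(=C/c2ccncc2)CN(S(=O)(=O)c2ccccc2)C/C1=C\c1ccccc1C(F)(F)F` is not yet measured. It carries the same change that turns compound 1 into compound 2, (phenylsulfonyl in place of hydrogen on an amine nitrogen in a ring), and the place is the same word for word, so this is the same change made on the core of compound 3. The expected step of a 1.0-fold lower number from compound 3 to compound 4 (0.02 log units; within the scatter) rests on the same change having given a 1.1-fold lower number from compound 1 to compound 2 (0.02 log units; within the scatter), a step within the scatter. Compound 4 is therefore expected near 4300 nM, between 2000 nM and 9500 nM.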

Compound 4, half-maximal inhibitory concentration: 6540 nM
Compound 4: middle estimate off by 1.5-fold (0.18 log units), on the low side, within the range that was stated.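

In this assay, phenylsulfonyl in place of hydrogen on an amine nitrogen in a ring gave a 1.5-fold higher number from compound 3 to compound 4 (0.16 log units; within the scatter), so on the second core the number again stayed within the scatter, and the two cores agree: the same change on two cores in this assay, a 1.1-fold lower number (0.02 log units; within the scatter) from compound 1 to compound 2 and a 1.5-fold higher number (0.16 log units; within the scatter) from compound 3 to compound 4, 1.5-fold (0.18 log units) apart, within the scatter of two such steps. Trifluoromethyl in place of fluoro gave a 2.7-fold lower number from compound 2 to compound 4 (0.43 log units; beyond the scatter), and that change also carried across: the same change on two cores in this assay, a 4.1-fold lower number (0.61 log units; beyond the scatter) from compound 1 to compound 3 and a 2.7-fold lower number (0.43 log units; beyond the scatter) from compound 2 to compound 4, 1.5-fold (0.18 log units) apart, within the scatter of two such steps. This shows that both changes transferred between these two closely related cores in this one cell assay, but it does not show that they would transfer to any other core.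

The compounds shown leave open whether methanesulfonyl or acetyl on that nitrogen would behave like phenylsulfonyl. They also leave open how chloro or methoxy would compare with trifluoromethyl.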